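Aryl swap at the oxazole position in a cytotoxicity series

The source may hold more compounds than are shown below. What is called first, only, known or untested is meant among the compounds shown, and "the series" means these compounds.

Three members of the series have been run in an ADME assay on MCF-10A cells (Homo sapiens) for cytotoxicity, read by MTT assay, with a stated time of 24 h; on this read-out higher numbers stand for weaker inhibition and lower numbers for stronger inhibition. Compound 1 `Fc1ccc(-n2cc(COc3ccccc3-c3nc4ccccc4s3)nn2)cc1Cl` gives 26300 nM. Compound 2 `FC(F)(F)Oc1ccc(-c2cc(COc3ccccc3-c3nc4ccccc4s3)on2)cc1` gives 43900 nM. Compound 3 `Brc1ccc(-c2cc(COc3ccccc3-c3nc4ccccc4s3)on2)cc1` gives 29200 nM. Compound 3 thus stands second highest of the three numbers; its nearest neighbour is compound 1, whose value lies within the scatter of it, and its furthest is compound 2, also within the scatter. Within the data shown here, the one step between compounds differing in a single place, a 1.5-fold lower number from compound 2 to compound 3 (0.18 log units; within the scatter), shows the aryl change at this position moving the number by an amount that cannot be told from repeat variation.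

Compound 4 `Fc1ccccc1-c1cc(COc2ccccc2-c2nc3ccccc3s2)on1` carries the same core and differs from compound 3 in one place: 2-fluorophenyl in place of 4-bromophenyl on an aromatic carbon. Among the measured compounds shown here, the only comparable step, from compound 2 to compound 3, was within the scatter, and compound 1, with a different aryl group at a related position, also sits within the scatter of compound 3. For the measured compounds named here, no measured step therefore supports a shift beyond the scatter in this assay for compound 4, in either direction. Compound 4 is expected at 30000 nM, with a plausible range from 15000 nM to 60000 nM, meaning an estimated step of a 1.0-fold higher number from compound 3 to compound 4 (0.01 log units; within the scatter) from compound 3.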

Compound 4, half-maximal inhibitory concentration: 42500 nM
Beside the measured number, compound 4's estimate is 1.4-fold (0.15 log units) below it, within the range that was stated.
By their numbers in this assay, from the lowest: compounds 1, 3, 4 and 2 (each within the scatter of the next).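

In this assay the aromatic carbon next to the ring nitrogen now carries 2-fluorophenyl as well as 4-bromophenyl and 4-(trifluoromethoxy)phenyl, and the new readings are a 1.5-fold higher number from compound 3 to compound 4 (0.16 log units; within the scatter) and a 1.0-fold lower number from compound 2 to compound 4 (0.01 log units; within the scatter) for these swaps. Until now this position had been read only between two groups substituted at the 4-position of the phenyl ring, so the series gains its first comparison with a fluoro group at the 2-position, and compounds 2, 3 and 4 cannot be told apart on this read-out. The swap from compound 3 to compound 4 alters both the halogen and its place on the phenyl ring, so the separate contribution of each cannot be read, and nothing available accounts for the flat response at this position.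

As far as these compounds go, the groups at this position are all phenyl rings bearing a halogen or trifluoromethoxy, so it remains open whether an amine or a carboxylic acid on that ring, or a longer alkyl chain in place of the ring, would give a step beyond the scatter. From the compounds shown here alone, compound 1 differs from the others in more than one place, so the part played by the ring bearing the aryl group also stays open.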